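The source may hold more compounds than are shown below. What is called first, only, known or untested is meant among the compounds shown, and "the series" means these compounds.

Compound 1 `Cc1ccccc1NC(=O)CCC(=O)OCCCCCCSc1ccc([N+](=O)[O-])c2nonc12` — 9490 nM
Compound 2 `O=C(CCC(=O)OCCCCCCSc1ccc([N+](=O)[O-])c2nonc12)Nc1cccc(Cl)c1` — 6930 nM
Compound 3 `O=C(CCC(=O)OCCCCCCSc1ccc([N+](=O)[O-])c2nonc12)Nc1ccc(F)cc1` — 6460 nM

All three were tested in an ADME assay on L02 cells (Homo sapiens) for cytotoxicity, read by MTT assay, with a stated time of 72 h; on this read-out higher numbers stand for weaker inhibition and lower numbers for stronger inhibition. In this assay compound 3 gives 6460 nM, and its number sits within the scatter of both neighbours: a 1.1-fold lower number from compound 2 to compound 3 (0.03 log units; within the scatter) and a 1.5-fold lower number from compound 1 to compound 3 (0.17 log units; within the scatter), so the three compounds cannot be separated on these numbers.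

Compound 4 `COc1ccc(NC(=O)CCC(=O)OCCCCCCSc2ccc([N+](=O)[O-])c3nonc23)cc1` differs from compound 3 by one change: methoxy in place of fluoro on an aromatic carbon. The three measured steps all replace one substituent on the same aryl ring of the amide nitrogen, and each stayed within the scatter: a 1.4-fold lower number from compound 1 to compound 2 (0.14 log units; within the scatter), a 1.5-fold lower number from compound 1 to compound 3 (0.17 log units; within the scatter), a 1.1-fold lower number from compound 2 to compound 3 (0.03 log units; within the scatter). No measured step exchanges a fluoro for a methoxy, so the step to compound 4 is not covered directly, but the pattern of the three aryl swaps gives no reason to expect a move beyond the scatter in this assay in either direction.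

Compound 4 is therefore estimated at 6500 nM, with a range of 3500 nM to 13000 nM, which would mean an expected step of a 1.0-fold higher number from compound 3 to compound 4 (0.00 log units; within the scatter).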

Compound 4, half-maximal inhibitory concentration: 8170 nM
Beside the measured number, compound 4's estimate is 1.3-fold (0.10 log units) below it, within the range that was stated.
By their numbers in this assay, from the lowest: compounds 3, 2, 4 and 1 (each within the scatter of the next).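

Methoxy in place of fluoro on this aromatic carbon, para to a large group, brings in a hydrogen-bond acceptor that fluoro does not have, yet this assay shows a 1.3-fold higher number from compound 3 to compound 4 (0.10 log units; within the scatter) as its step. The two longer comparisons, a 1.2-fold higher number from compound 2 to compound 4 (0.07 log units; within the scatter) and a 1.2-fold lower number from compound 1 to compound 4 (0.07 log units; within the scatter), also stay inside the scatter, so the 4-methoxyphenyl amide cannot be separated from the 3-chlorophenyl, 2-methylphenyl or 4-fluorophenyl amides, and all four aryl groups shown read alike here. No supporting data bear on this result.

The compounds shown leave open whether an amine or a carboxylic acid on this aryl ring would give a step beyond the scatter. They also leave open whether a longer chain linking the ester to the sulfur would do so.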